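The source may hold more compounds than are shown below. What is called first, only, known or untested is meant among the compounds shown, and "the series" means these compounds.

Compound 1 `O=C(CCCCC1CCSS1)NCc1cn(CCCCOc2ccc3cc(-c4ccc(Br)cc4)c(=O)oc3c2)nn1` and compound 2 `O=C(CCCCC1CCSS1)NCc1cn(CCCCOc2ccc3cc(-c4ccc(Cl)c(Cl)c4)c(=O)oc3c2)nn1` share a core and differ in one place. In a functional assay on PC-12 cells (Rattus norvegicus) for cytotoxicity, read by MTT assay, with stated times of 3 h and 2 h, tested at 20 uM (on this read-out lower numbers stand for a weaker effect and higher numbers for a stronger effect at the one concentration tested), compound 1 gives 45%, and compound 2 gives 62.9%. The change between them is 3,4-dichlorophenyl in place of 4-bromophenyl on an aromatic carbon, and it gives a number 17.9 percentage points higher from compound 1 to compound 2 (beyond the scatter). Compound 3 `O=C(CCCCC1CCSS1)NCc1cn(CCCCCOc2ccc3cc(-c4ccc(Br)cc4)c(=O)oc3c2)nn1` carries the same 4-bromophenyl as compound 1 on a different core; how the two cores differ is not broken down here. In this assay compound 3 gives 52.3%, which lies within the scatter of the value of compound 1 and below that of compound 2 by more than the scatter.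

Compound 4 `O=C(CCCCC1CCSS1)NCc1cn(CCCCCOc2ccc3cc(-c4ccc(Cl)c(Cl)c4)c(=O)oc3c2)nn1` has not yet been measured in this assay. It stands to compound 3 as compound 2 stands to compound 1: the change is 3,4-dichlorophenyl in place of 4-bromophenyl on an aromatic carbon, the same change at the same place. On the core of compound 1 this change gave a number 17.9 percentage points higher from compound 1 to compound 2 (beyond the scatter), and on that basis a step of a number 16.7 percentage points higher from compound 3 to compound 4 (beyond the scatter) is expected from compound 3 to compound 4, with the reservation that the change has been seen only once. Compound 4 is expected to give about 69% in this assay, between 57% and 80%.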

Compound 4, a percentage reported as activity, at one concentration (the size of the read-out at that concentration, not a potency): 65.5%
Compound 4: the middle estimate sits 3.5 percentage points above what was measured; low and high end bracket the measured number.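

In this assay, 3,4-dichlorophenyl in place of 4-bromophenyl gives a number 13.2 percentage points higher from compound 3 to compound 4 (beyond the scatter), so the change points the same way on the second core as on the first. Set beside each other, the two steps do not differ in size: the same change on two cores in this assay, a number 17.9 percentage points higher (beyond the scatter) from compound 1 to compound 2 and a number 13.2 percentage points higher (beyond the scatter) from compound 3 to compound 4, 4.7 percentage points apart, within the scatter of two such steps. This supports carrying the change between these two cores, but it rests on two pairs, one exchange of groups and a single concentration, so it neither extends to other cores nor explains why the number rises.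

Open, on these data alone, is how a phenyl carrying a nitrile, a methoxy group, an amine or a carboxylic acid in place of the halogens would read in this assay. Also open, as far as these compounds go, is whether the step persists with a chain longer than that of compound 3 and compound 4.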